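The source may report more compounds than this note shows. Statements on the series, on what has been measured and on what is new or still open speak of the compounds shown alone.

Measured in a functional assay on KB cells (Homo sapiens) for cytotoxicity, read by MTT assay, with a stated time of 72 h; a higher number here means a weaker inhibitor, a lower number a stronger inhibitor:
- Compound 1 `COc1ccc(S(=O)(=O)c2nc3ccccc3nc2N2CCc3ccccc3C2)cc1`: > 50000 nM, a limit of the assay
- Compound 2 `O=S(=O)(c1ccc(F)cc1)c1nc2ccccc2nc1N1CCc2ccccc2C1`: 35400 nM

Compound 1 has no exact number and stands only at the limit of > 50000 nM in this assay, at which 1 of the 2 values shown sits. Compound 3 `COc1ccc(S(=O)(=O)c2nc3ccccc3nc2N2CCCC(O)C2)cc1` keeps the core of compound 1 and differs from it in one place: 3-hydroxypiperidin-1-yl in place of 1,2,3,4-tetrahydroisoquinolin-2-yl on an aromatic carbon. In words, this is 3-hydroxypiperidin-1-yl in place of 1,2,3,4-tetrahydroisoquinolin-2-yl on an aromatic carbon, next to the ring nitrogen.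

For the measured compounds named here, only one measured step is available: an at least 1.4-fold lower number from compound 1 to compound 2 (0.14 log units; that floor lies within the scatter). That step is fluoro in place of methoxy on an aromatic carbon, so it leaves the 1,2,3,4-tetrahydroisoquinolin-2-yl group untouched. Going by the values given here, it bears on the present change only indirectly, and no measured compound carries 3-hydroxypiperidin-1-yl. With so little to go on, no step beyond the scatter can be forecast in this assay, in either direction, and the assay may again report only a limit. The expected step is a number no higher from compound 1 to compound 3 (the limit leaves the size open). Compound 3 is expected at 50000 nM, with an estimated range from 20000 nM to 120000 nM.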

Compound 3, half-maximal inhibitory concentration: 2120 nM
Estimate against measurement, compound 3: 24-fold (1.37 log units) above; measured number below the stated range.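

In this assay, for the compounds shown here, the group on this aromatic carbon, next to the ring nitrogen, proves far more telling than the one earlier change: 3-hydroxypiperidin-1-yl in place of 1,2,3,4-tetrahydroisoquinolin-2-yl gives an at least 23-fold lower number from compound 1 to compound 3 (1.37 log units; beyond the scatter), whereas fluoro in place of methoxy gave only an at least 1.4-fold lower number from compound 1 to compound 2 (0.14 log units; that floor lies within the scatter). The change removes the six-membered aromatic ring of the leaving group and brings in a hydroxyl, and the data cannot separate these two differences. The size of the step is only a floor, and compound 1 stands only at a limit: the limit of > 50000 nM in this assay, at which 1 of the 3 values shown sits.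

From the compounds shown here alone, whether a plain piperidin-1-yl, a morpholin-4-yl or a 3-aminopiperidin-1-yl on this carbon would give a similar number stays open, and with it the question of whether the hydroxyl or the loss of the aromatic ring carries the step. Going by these compounds alone, also open is whether fluoro in place of methoxy, so far seen only with the 1,2,3,4-tetrahydroisoquinolin-2-yl group, would shift the number of compound 3 at all.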